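This account rests on a few compounds, and the source may have more. Where it says the series, first, only, none or still open, it means among the compounds named here.

Measured compounds in an in vitro assay on SH-EP1 cells for displacement of a labelled ligand from Neuronal acetylcholine receptor; alpha4/beta2 (Homo sapiens); a higher number here means a weaker inhibitor, a lower number a stronger inhibitor:
compound 1 `Clc1ccc(Oc2cncc(C3=CC4CNCC(C3)C4)c2)cc1`: 1.9 nM
compound 2 `C1=C(c2cnccn2)CC2CNCC1C2`: 1.1 nM
compound 3 `C1=C(c2ccc(-c3ccccc3)nc2)CC2CNCC1C2`: 105 nM

Compound 1 sits second highest of the three numbers. Its nearest neighbour is compound 2, which lies within the scatter, so the two cannot be placed in order. Compound 3 lies far beyond the scatter from compound 1, with the much higher number of the set.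

The next compound, compound 4 `COc1ccc(Oc2cncc(C3=CC4CNCC(C3)C4)c2)cc1`, is compound 1 with methoxy in place of chloro on an aromatic carbon. No pair of measured compounds differs in this way, so there is no shown step to lean on. The change is small and sits on the outer ring; no shift beyond the scatter is expected in this assay, and the estimated step of a 1.3-fold higher number from compound 1 to compound 4 (0.12 log units; within the scatter) is modest. Compound 4 is estimated at 2.5 nM, with a range of 1 nM to 6.5 nM.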

Compound 4, inhibition constant: 1.4 nM
Compound 4: the middle estimate sits 1.8-fold (0.25 log units) above what was measured; measured number inside the range.
By their numbers in this assay, from the lowest: compounds 2, 4 and 1 (each within the scatter of the next); then compound 3.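

In this assay, for the compounds shown here, the change from 4-chlorophenyl to 4-methoxyphenyl gives the first step between compounds differing in one place: a 1.4-fold lower number from compound 1 to compound 4 (0.13 log units; within the scatter). At this position, para to a large group, chloro and methoxy cannot be told apart, even though methoxy carries a hydrogen-bond acceptor that chloro lacks. Nothing available accounts for this result. Still open, on these data alone, is whether an amine, a carboxylic acid or a longer chain such as butoxy at the same position would also stay within the scatter of compound 1.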